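A few compounds are considered here, and "the series" means these few. Any claim that something is new, unique, unknown or untested is made for them only; others in the source may bear on it.

Working notes on the series. In a functional assay on HeLa cells (Homo sapiens) for inhibition, read by colorimetric assay, with a stated time of 3 days (a lower number here means a stronger inhibitor, a higher number a weaker inhibitor), compound 1 (`O=C(CCCCCCNC(=O)C(O)(O)C(F)(F)F)Nc1ncc(-c2ccc(Br)cc2)s1`) gives 1220 nM and compound 2 (`COc1ccc2sc(NC(=O)CCCCCCNC(=O)C(O)(O)C(F)(F)F)nc2c1`) gives 1860 nM as its half-maximal inhibitory concentration. These two values lie within the usual scatter of each other, so compound 2 stands level with compound 1 and no ranking can be drawn from them.

Compound 3 (`O=C(CCCCCCNC(=O)C(O)(O)C(F)(F)F)Nc1nc2ccccc2s1`) is compound 2 with hydrogen in place of methoxy on an aromatic carbon and is otherwise unchanged. Among the measured compounds shown here, no measured pair isolates this replacement, so its size has to be judged indirectly. Compound 1 at 1220 nM and compound 2 at 1860 nM sit within the scatter although their structures differ in more than one place. On that basis, no step beyond the scatter is expected in this assay for this single replacement, and neither direction is favoured.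

The value expected for compound 3 is 2000 nM with an estimated range from 800 nM to 5000 nM in this measurement. The estimate means a 1.1-fold higher number from compound 2 to compound 3 (0.03 log units; within the scatter) as the expected step, which would stay within the scatter.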

Compound 3, half-maximal inhibitory concentration: 1520 nM
For compound 3 the middle estimate is 1.3-fold (0.12 log units) above the measured one; measured number inside the range.
By their numbers in this assay, from the lowest: compounds 1, 3 and 2 (each within the scatter of the next).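

This position now has its first measured single-place step: hydrogen in place of methoxy, on an aromatic carbon of the six-membered aromatic ring of carbon only, meta to a fused ring and para to a fused ring, gives a 1.2-fold lower number from compound 2 to compound 3 (0.09 log units; within the scatter) in this assay. The two compounds therefore stand level, and taking away the two heavy atoms and the hydrogen-bond acceptor of the methoxy group leaves no readable mark on the number in this assay, so methoxy is not needed at this place to hold the level of compound 2. Nothing at hand bears on why the step is this small.

The compounds shown leave open whether another group on this aromatic carbon, such as an amine, a carboxylic acid or a fluorine atom, would give a step beyond the scatter, as methoxy and hydrogen are the only two groups compared here. They also leave open whether the same replacement would stay within the scatter on a compound carrying a longer chain.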